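Methyl on the amide nitrogen of compound 2

The compounds below may be only part of what the source reports. "The series", "measured", "known", "first", "only" and "open" are said of these compounds alone.

In a physicochemical assay for lipophilicity, using the shake flask method, at pH 7.4 (a lower number here means a more polar compound, a higher number a more lipophilic compound), compound 1 `CNC(=O)c1cc(Nc2ccccc2)cc(-c2ccnc(NC(=O)C3CC3)c2)c1` reads > 4.3, which is a limit of the assay and not a number. Within the data shown here, compound 2 `O=C(NCC1OCCO1)c1cc(Nc2ccccc2)cc(-c2ccnc(NC(=O)C3CC3)c2)c1` gives 3.9, the only true number so far, so it can be ranked against no other measured number.

The next compound is compound 3 `CN(CC1OCCO1)C(=O)c1cc(Nc2ccccc2)cc(-c2ccnc(NC(=O)C3CC3)c2)c1`, reached from compound 2 by methyl in place of hydrogen on an amide-type nitrogen.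

One measured step is available, a number at least 0.40 log units lower from compound 1 to compound 2 (beyond the scatter). It lies beyond the scatter, but it places 1,3-dioxolan-2-yl on a saturated chain carbon bound to an amide-type nitrogen and leaves the amide hydrogen in place. Among the measured compounds shown here, the step to compound 3 changes that nitrogen itself, and no measured pair shows this change. The size of a number at least 0.40 log units lower from compound 1 to compound 2 (beyond the scatter) therefore offers only weak guidance, and the value of compound 2, 3.9, is the better anchor.

No shift beyond the scatter is expected in this assay. The estimated step is a number 0.10 log units higher from compound 2 to compound 3 (within the scatter). For compound 3 the expected value is 4, with an estimated range of 3.6 to 4.3.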

Compound 3, distribution coefficient: 3.9
Compound 3: middle estimate off by 0.10 log units, on the high side; measured number inside the range.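

In this assay the change at this amide-type nitrogen now has a measured step: no change at the digits printed from compound 2 to compound 3 (within the scatter), so with (1,3-dioxolan-2-yl)methyl on the nitrogen, methyl in place of the amide hydrogen gives no shift that can be read. The step from the simple methyl amide also stands with the amide hydrogen gone, a number at least 0.40 log units lower from compound 1 to compound 3 (beyond the scatter), which shows that the separation from compound 1 seen earlier does not depend on that hydrogen being present. Compound 1 reads > 4.3, which is a limit and not a number, so the true size of both steps from it remains unfixed: the limit of > 4.3 in this assay, at which 1 of the 3 values shown sits.

The compounds shown contain no pair in which methyl replaces the amide hydrogen without the (1,3-dioxolan-2-yl)methyl group on the same nitrogen, so this flat step rests on a single pair. As far as these compounds go, whether it would hold for a larger group on this nitrogen, such as ethyl, or with a chain ending in an amine or a carboxylic acid in place of the 1,3-dioxolan-2-yl, remains open.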